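Methylsulfanyl in Place of Cyclohexyl on the Ether Chain

A few compounds are considered here, and "the series" means these few. Any claim that something is new, unique, unknown or untested is made for them only; others in the source may bear on it.

Compound 2 `Nc1ccc2cccc(OCCC3CCCCC3)c2n1` gives 808 nM in an assay on cells with melanin-concentrating hormone receptor 1 (Homo sapiens) as the target, read by radioligand binding; a lower number here means a stronger inhibitor, a higher number a weaker inhibitor. Compound 1 `CC1CCC(Oc2cccc3ccc(N)nc23)C1` gives 823 nM and compound 3 `Nc1ccc2cccc(OCCC3CC3)c2n1` gives 492 nM; on the numbers as they stand compound 2 has the second highest, yet all three lie within the scatter of one another, so no real separation is shown. Compound 4 `CSCCOc1cccc2ccc(N)nc12` has not yet been measured. Its change from compound 2 is methylsulfanyl in place of cyclohexyl on a saturated chain carbon, two bonds along the chain from an oxygen on an aromatic ring. The step that bears on it most is a 1.6-fold lower number from compound 2 to compound 3 (0.22 log units; within the scatter), an exchange at the same place on the chain; a 1.7-fold lower number from compound 1 to compound 3 (0.22 log units; within the scatter) is likewise within the scatter. Since both earlier exchanges left the number essentially unchanged, compound 4 is expected to show no step beyond the scatter, a 1.3-fold lower number from compound 2 to compound 4 (0.13 log units; within the scatter). Compound 4 is therefore estimated at 600 nM, ranging from 250 nM to 1500 nM.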

Compound 4, half-maximal inhibitory concentration: > 2000 nM
Compound 4 ended at the assay's limit; the forecaster's own chance of this, stated with the estimate: 5%; at least 3.3-fold (0.52 log units) between middle value and limit.
By their numbers in this assay, from the lowest: compounds 3, 2 and 1 (each within the scatter of the next). At a limit, above all of these: compound 4.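

In this assay compound 4 ended at a limit and not at a number: the limit of > 2000 nM in this assay, at which 1 of the 4 values shown sits. The steps to it lie beyond the scatter, as an at least 2.4-fold higher number from compound 2 to compound 4 (0.39 log units; beyond the scatter), an at least 4.0-fold higher number from compound 3 to compound 4 (0.60 log units; beyond the scatter) and an at least 2.4-fold higher number from compound 1 to compound 4 (0.38 log units; beyond the scatter) show. The ether chain therefore tolerates some exchanges but not all: cyclohexyl, cyclopropyl and 3-methylcyclopentyl stayed within the scatter of one another, and methylsulfanyl did not.

From the compounds shown here alone, what stays open is whether this follows from the sulfur atom or from the loss of a ring. Methoxy or a plain propyl group in the same place would separate the two, and an amine would show how a different kind of group fares there.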